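Dichlorophenyl to fluorophenyl on the biaryl of the lactone series

The compounds below may be only part of what the source reports. "The series", "measured", "known", "first", "only" and "open" are said of these compounds alone.

Among the compounds with values here, compound 2 `O=C1C[C@H](O)C[C@@H](/C=C/c2c(Cl)cc(Cl)cc2-c2cc(Cl)cc(Cl)c2)O1` holds the lowest of the two numbers measured so far in an assay for inhibition of 3-hydroxy-3-methylglutaryl-coenzyme A reductase (Rattus norvegicus) (on this read-out lower numbers stand for stronger inhibition and higher numbers for weaker inhibition), where compound 2 gives 37 nM. Within the data shown here, its nearest neighbour is compound 1 `O=C1C[C@H](O)C[C@@H](/C=C/c2c(Cl)cc(Cl)cc2-c2ccccc2)O1`, which in this assay gives 80 nM; the only step measured, a 2.2-fold lower number from compound 1 to compound 2 (0.33 log units; beyond the scatter), is modest but beyond the scatter.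

Compound 3 `O=C1C[C@H](O)C[C@@H](/C=C/c2c(Cl)cc(Cl)cc2-c2cccc(F)c2)O1` has not yet been measured in this assay. It differs from compound 2 at a single place, (3-fluorophenyl in place of 3,5-dichlorophenyl on an aromatic carbon). The step from compound 1 to compound 2 is the only one that bears on this change: adding two chloro groups to the phenyl gave a 2.2-fold lower number from compound 1 to compound 2 (0.33 log units; beyond the scatter). Compound 3 carries a single fluorine on that ring in place of the two chloro groups, so the change is a partial reversal of the one measured, and the number is expected to move back toward that of compound 1, but not all the way, giving a 1.6-fold higher number from compound 2 to compound 3 (0.21 log units; within the scatter) as the expected step.

Compound 3 is therefore estimated at 60 nM in this assay, with a range of 30 nM to 140 nM.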

Compound 3, half-maximal inhibitory concentration: 70 nM
The estimate for compound 3 lay 1.2-fold (0.07 log units) below the measured number; the range from low to high includes it.
By their numbers in this assay, from the lowest: compounds 2, 3 and 1 (each within the scatter of the next, the first and the last beyond it).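

Fluoro on the phenyl is the new change at this position, and in this assay it cannot be told apart from hydrogen (a step of a 1.1-fold lower number from compound 1 to compound 3 (0.06 log units; within the scatter)). The exchange of 3,5-dichlorophenyl for 3-fluorophenyl also stays inside the usual variation between repeats (a step of a 1.9-fold higher number from compound 2 to compound 3 (0.28 log units; within the scatter)), so compound 3 is separated from neither neighbour, and only the two outer compounds remain apart (a step of a 2.2-fold lower number from compound 1 to compound 2 (0.33 log units; beyond the scatter)). The single measured gain on this ring therefore belongs to the pair of compound 1 and compound 2 alone, and no information on these compounds accounts for the size of any of these steps.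

The compounds shown leave open whether that gain follows the number of halogens or their kind, a question that a single chloro group or two fluoro groups on this ring would address. As far as these compounds go, how far this position tolerates a different kind of group, such as an amine, a carboxylic acid or a methoxy group, also remains unknown.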